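The source may hold more compounds than are shown below. What is called first, only, known or untested is meant among the compounds shown, and "the series" means these compounds.

Measured compounds:
Compound 1, `COc1cc(/C=C/C(=O)C2=C(/C=C/c3ccc(O)c(OC)c3)NC(=O)NC2c2ccc(N(C)C)cc2)ccc1O`: 12500 nM
Compound 2, `COc1cc(/C=C/C(=O)C2=C(/C=C/c3ccc(O)c(OC)c3)NC(=O)NC2c2c(Cl)cccc2Cl)ccc1O`: 100000 nM
Compound 3, `COc1cc(/C=C/C(=O)C2=C(/C=C/c3ccc(O)c(OC)c3)NC(=S)NC2c2ccc(N(C)C)cc2)ccc1O`: 25000 nM

All three were tested in a functional assay on QG-56 cells (Homo sapiens) for cytotoxicity, read by MTT assay, with a stated time of 48 h; a lower number here means a stronger inhibitor, a higher number a weaker inhibitor. Compound 1 and compound 2 share one core and differ in a single place: 2,6-dichlorophenyl in place of 4-(dimethylamino)phenyl on a saturated ring carbon. This change gave an 8.0-fold higher number from compound 1 to compound 2 (0.90 log units; beyond the scatter), so compound 2 is the weaker of the two.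

Compound 3 has a different core from compound 1, and the difference between the two cores is not broken down here; what can be said is only what the two values show. In this assay compound 3 gives 25000 nM, and compound 1 gives 12500 nM, a gap that lies within the usual scatter.

Compound 4, `COc1cc(/C=C/C(=O)C2=C(/C=C/c3ccc(O)c(OC)c3)NC(=S)NC2c2c(Cl)cccc2Cl)ccc1O`, has not yet been measured. It stands to compound 3 as compound 2 stands to compound 1: 2,6-dichlorophenyl in place of 4-(dimethylamino)phenyl on a saturated ring carbon. The place of the change is described in the same words for both pairs, so it is the same change made on the other core. Because the first instance gave an 8.0-fold higher number from compound 1 to compound 2 (0.90 log units; beyond the scatter), a step of similar size from compound 3 to compound 4 is expected, namely a 4.0-fold higher number from compound 3 to compound 4 (0.60 log units; beyond the scatter). This rests on a single earlier example, so the expectation is uncertain. For compound 4 the estimated value in this assay is 100000 nM, with a plausible range from 40000 nM to 250000 nM.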

Compound 4, half-maximal inhibitory concentration: 100000 nM
Compound 4: the middle estimate sits on the measured number at the digits printed, within the range that was stated.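

In this assay, putting 2,6-dichlorophenyl in place of 4-(dimethylamino)phenyl on the saturated ring carbon gave a 4.0-fold higher number from compound 3 to compound 4 (0.60 log units; beyond the scatter), so compound 4 is the weaker of this pair. Among these compounds, the same change pointed the same way on both cores, and the two steps cannot be told apart in size: the same change on two cores in this assay, an 8.0-fold higher number (0.90 log units; beyond the scatter) from compound 1 to compound 2 and a 4.0-fold higher number (0.60 log units; beyond the scatter) from compound 3 to compound 4, 2.0-fold (0.30 log units) apart, within the scatter of two such steps This shows that, for these two cores, the effect of the change carried over from one to the other, but with only two examples it does not show that the change would behave the same way on any further core, and it gives no reason why the numbers move as they do.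

The compounds shown leave open which part of the change matters, since the 4-(dimethylamino)phenyl group leaves and the 2,6-dichlorophenyl group enters in one step, so the effect of each cannot be separated. Other groups on the same saturated ring carbon, such as a plain phenyl ring, a phenyl ring with a single methoxy group or one with a carboxylic acid, would help to show where along this range of groups the numbers rise.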